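The source may hold more compounds than are shown below. What is called first, only, known or untested is meant among the compounds shown, and "the series" means these compounds.

Series notes, an assay on isolated protein for displacement of a labelled ligand from growth hormone secretagogue receptor type 1 (Homo sapiens), with a stated time of 1 h; on this read-out lower numbers stand for stronger inhibition and higher numbers for weaker inhibition:
- compound 1 `CN(c1ccccc1CCCn1nnnc1[C@@H](COCc1ccccc1)NC(=O)C(C)(C)N)S(C)(=O)=O` gives 1720 nM.
- compound 2 `COC(=O)C(c1ccccc1)n1nnnc1[C@@H](COCc1ccccc1)NC(=O)C(C)(C)N` gives 470 nM.
- compound 3 `CC(C)(N)C(=O)N[C@H](COCc1ccccc1)c1nnn(Cc2ccc(NS(C)(=O)=O)cc2)n1` gives only a limit of the assay, > 5000 nM.

From the compounds shown here alone, compound 3 therefore stands at the weak end of what has been measured so far; it sits at the limit of > 5000 nM in this assay, at which 1 of the 3 values shown sits, so its true value remains unknown. Compound 4 `CC(C)(N)C(=O)N[C@H](COCc1ccccc1)c1nnn(C/C=C/c2ccccc2)n1` differs from compound 3 by 2-phenylethenyl in place of 4-(methanesulfonamido)phenyl on a saturated chain carbon bound to an aromatic nitrogen. Among the measured compounds shown here, no step between two measured compounds covers this change, so the size of the step in this assay cannot be read from the data; a move into the measurable range is expected, but of uncertain size. The expected step from compound 3 to compound 4 is an at least 1.6-fold lower number from compound 3 to compound 4 (0.22 log units; that floor lies within the scatter). Compound 4 is expected to come in near 3000 nM, with a range from 800 nM to 10000 nM.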

Compound 4, inhibition constant: > 5000 nM
Compound 4 was reported as a limit; the forecaster's own chance of this, stated with the estimate: 30%; middle value at least 1.6-fold (0.22 log units) away from the limit.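

Among the compounds shown here, compound 3 and compound 4 both stand at a limit of the assay, so no step between them can be read: the limit of > 5000 nM in this assay, at which 2 of the 4 values shown sit. The compounds shown leave open where the true values of compound 3 and compound 4 lie, and whether 2-phenylethenyl in place of 4-(methanesulfonamido)phenyl changes the read-out at all.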